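Agonist series: ethyl in place of hydrogen

The source may report more compounds than this note shows. Statements on the series, on what has been measured and on what is new or still open speak of the compounds shown alone.

Compound 1 `CCCCCCCC/C=C\CCCCCCCC(=O)O[C@H](C)COP(=O)(O)OC[C@H](N)C(=O)O`: 11.4%
Compound 2 `CCCCCCCC/C=C\CCCCCCCC(=O)OC[C@@H](COC)OP(=O)(O)OC[C@H](N)C(=O)O`: "not active" (no number reported)

In an assay on HEK293 cells for agonist activity at putative P2Y purinoceptor 10 (Mus musculus), with a stated time of 1 h (on this read-out higher numbers stand for larger maximal responses and lower numbers for smaller maximal responses), compound 1 gives 11.4%, while compound 2 is reported only as "not active" (no number reported), with no number, so compound 2 stands without a single value to set against compound 1. Compound 3 `CCCCCCCC/C=C\CCCCCCCC(=O)OC[C@@H](COCCC)OP(=O)(O)OC[C@H](N)C(=O)O` differs from compound 2 by ethyl in place of hydrogen on a saturated chain carbon bound to an oxygen on a saturated carbon. Among the measured compounds shown here, no measured pair carries this change, so no step size is known; in this assay the expectation for compound 3 is a shift no larger than the scatter, with no firm direction. Compound 3 is expected to reach 8%, within a range from 0% to 25%.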

Compound 3, largest response reached (Emax), in percent of the reference or control that the assay uses: "not active" (no number reported)
Compound 3: no number reported, so the estimate cannot be set against anything.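

Compound 2 and compound 3 both carry no number, so no step can be read between them. The compounds shown leave open whether methoxy to propoxy changes the response at all. No supporting evidence bears on this result.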